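Swapping 1H-pyrazol-3-yl for 1H-imidazol-1-yl on a shared core

The source may report more compounds than this note shows. Statements on the series, on what has been measured and on what is new or still open speak of the compounds shown alone.

Measured in a physicochemical assay for lipophilicity, at pH 7.4; a lower number here means a more polar compound, a higher number a more lipophilic compound:
compound 1 `CCOc1ccc2c(c1)C=CN(C)C(=O)C2C`: 5
compound 2 `CCOc1ccc2c(c1)C(c1cc[nH]n1)=CN(C)C(=O)C2C`: 3.8

Of these two compounds, compound 2 holds the lowest number. For the measured compounds named here, the one measured step, a number 1.20 log units lower from compound 1 to compound 2 (beyond the scatter), came with 1H-pyrazol-3-yl in place of hydrogen on a double-bonded ring carbon, and it was large.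

Compound 3 `CCOc1ccc2c(c1)C(n1ccnc1)=CN(C)C(=O)C2C` has not yet been measured. It carries 1H-imidazol-1-yl in place of 1H-pyrazol-3-yl on that same carbon: 1H-imidazol-1-yl in place of 1H-pyrazol-3-yl on a double-bonded ring carbon. The two compounds have the same atoms, joined differently. Going by the values given here, the measured step bears on this only indirectly, as it adds a ring rather than exchanging one, and no measured step covers such an exchange. Starting from compound 2 at 3.8, no change beyond the scatter is expected, and the estimated step is a number 0.20 log units lower from compound 2 to compound 3 (within the scatter). For compound 3 the expected value is 3.6, within an estimated range from 3 to 4.2.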

Compound 3, distribution coefficient: 4.3
Compound 3: the middle estimate sits 0.70 log units below what was measured; the measured number lies above the stated range.
By their numbers in this assay, from the lowest: compound 2; then compound 3; then compound 1.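

In this assay the two rings are not interchangeable on this double-bonded ring carbon: with the same atoms joined differently, a number 0.50 log units higher from compound 2 to compound 3 (beyond the scatter) came with 1H-imidazol-1-yl in place of 1H-pyrazol-3-yl. Measured against the unsubstituted compound, the ring added at this carbon also sets the size of the drop, with a number 0.70 log units lower from compound 1 to compound 3 (beyond the scatter) for 1H-imidazol-1-yl and a number 1.20 log units lower from compound 1 to compound 2 (beyond the scatter) for 1H-pyrazol-3-yl. Nothing available explains why the two rings differ here.

On these data alone, only these two rings are compared on this carbon, so it remains open whether the hydrogen-bond donor of 1H-pyrazol-3-yl, which 1H-imidazol-1-yl lacks, or some other difference between them goes with the shift. As far as these compounds go, how a phenyl ring or a primary amide on the same carbon would compare also stays open.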